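Swapping a dichlorophenyl for a carbamoyl group

The source may report more compounds than this note shows. Statements on the series, on what has been measured and on what is new or still open speak of the compounds shown alone.

Compound 1 `CCOc1nc(N)nc2ncc(-c3ccc(Cl)c(Cl)c3)nc12` gives > 10000 nM in a functional assay on cells (T-cell, Homo sapiens) for inhibition (on this read-out lower numbers stand for stronger inhibition and higher numbers for weaker inhibition), which is a limit of the assay rather than a number, as the limit of > 10000 nM in this assay, at which 1 of the 2 values shown sits, shows. Compound 2 `COc1ccc(-c2cnc3nc(N)nc(N4CCN(c5cc(Cl)cc(Cl)c5)CC4)c3n2)cc1OC` gives 3400 nM in this assay, the only number shown so far. Compound 3 `COc1ccc(-c2cnc3nc(N)nc(N4CCN(C(=O)Nc5cccc(C)c5)CC4)c3n2)cc1OC` differs from compound 2 in one place: (3-methylphenyl)carbamoyl in place of 3,5-dichlorophenyl on an amine nitrogen in a ring. Within the data shown here, no measured pair shows what this kind of exchange does, so its direction is open. Compound 3 is estimated to give 3500 nM in this assay, within 600 nM to 20000 nM. The step of a 1.0-fold higher number from compound 2 to compound 3 (0.01 log units; within the scatter) is expected to stay within the usual scatter.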

Compound 3, half-maximal inhibitory concentration: 7 nM
For compound 3 the middle estimate is 500-fold (2.70 log units) above the measured one; measured number outside the range, below it.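

In this assay, the group on this amine nitrogen in a ring matters greatly: (3-methylphenyl)carbamoyl in place of 3,5-dichlorophenyl brings a 490-fold lower number from compound 2 to compound 3 (2.69 log units; beyond the scatter). Among these compounds, the earlier compounds offered no such pair, so this is the first sign of how strongly the position responds to what it carries. Nothing measured here accounts for the size of this step.

Going by these compounds, it remains open whether the carbamoyl link or the methyl group carries the change. A plain phenylcarbamoyl, or a methoxy or chlorine in place of the methyl, could help separate the two.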